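This account rests on a few compounds, and the source may have more. Where it says the series, first, only, none or still open, it means among the compounds named here.

Compound 1, `CC1CCN(Cc2ccc3nc(NC(=O)N/N=C/c4cn(Cc5cccc(Cl)c5)c5ccccc45)sc3c2)CC1`: 280 nM
Compound 2, `CCN(CC)Cc1ccc2nc(NC(=O)N/N=C/c3cn(Cc4cccc(Cl)c4)c4ccccc34)sc2c1`: 220 nM
Compound 3, `CN(C)Cc1ccc2nc(NC(=O)N/N=C/c3c[nH]c4ccccc34)sc2c1`: 2550 nM

In a functional assay on NCI-H460 cells (Homo sapiens) for cytotoxicity, read by MTT assay, with a stated time of 72 h (a lower number here means a stronger inhibitor, a higher number a weaker inhibitor), compound 2 gives 220 nM. Compound 1 stands close beside it, since a 1.3-fold lower number from compound 1 to compound 2 (0.10 log units; within the scatter), so the two cannot be told apart. Compound 3 differs from compound 2 in several places at once. In this assay compound 3 gives 2550 nM, a number clearly apart from that of compound 2.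

Compound 4, `CCN(CC)Cc1ccc2nc(NC(=O)N/N=C/c3cn(Cc4ccc(Cl)cc4)c4ccccc34)sc2c1`, has not yet been measured in this assay. It differs from compound 2 in one place only: 4-chlorophenyl in place of 3-chlorophenyl on a saturated chain carbon bound to an aromatic nitrogen.

Among the measured compounds shown here, none of the measured steps touches this part of the molecule. For the measured compounds named here, the one single-place step, a 1.3-fold lower number from compound 1 to compound 2 (0.10 log units; within the scatter), moved a different group and stayed within the scatter; compound 3 changes several things at once and offers no reading on the chlorophenyl alone. There is therefore nothing in the numbers to suggest a shift in either direction, and the step of a 1.1-fold higher number from compound 2 to compound 4 (0.06 log units; within the scatter) is expected to remain within the scatter.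

On that basis compound 4 is estimated to give 250 nM in this assay, with a range from 100 nM to 650 nM.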

Compound 4, half-maximal inhibitory concentration: 370 nM
Compound 4: middle estimate off by 1.5-fold (0.17 log units), on the low side, and the stated range covers the measured number.
By their numbers in this assay, from the lowest: compounds 2, 1 and 4 (each within the scatter of the next); then compound 3.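

In this assay, replacing 3-chlorobenzyl with 4-chlorobenzyl gives a 1.7-fold higher number from compound 2 to compound 4 (0.23 log units; within the scatter), so compound 2 and compound 4 cannot be told apart in this measurement. Among the compounds shown here, this is the first direct reading at the saturated chain carbon bound to an aromatic nitrogen, since the earlier single-place step, a 1.3-fold lower number from compound 1 to compound 2 (0.10 log units; within the scatter), concerned a different group, and it shows that for this pair the two chlorophenyl forms give numbers within the usual scatter of each other. No further data accompany these numbers, so the result stands as an observation without an explanation.

The two chlorophenyl forms say nothing yet about how a 2-chlorophenyl, an unsubstituted phenyl, a 4-fluorophenyl or a 4-methoxyphenyl group would read at this place, or about a longer chain between the ring and the aromatic nitrogen. It also remains open whether the same match between the 3-chlorophenyl and 4-chlorophenyl forms would hold with 4-methylpiperidin-1-yl in place of diethylamino, as the pair shown here carries only the diethylamino group.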